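Adding 3,4-dichlorobenzyl to compound 2

This account rests on a few compounds, and the source may have more. Where it says the series, first, only, none or still open, it means among the compounds named here.

Values in a functional assay on MDA-MB-231 cells (Homo sapiens) for cytotoxicity, read by MTT assay, with a stated time of 72 h; a higher number here means a weaker inhibitor, a lower number a stronger inhibitor 
compound 1 `CCN(CC)Cc1ccc2nc(NC(=O)N/N=C/c3cn(Cc4cccc(Cl)c4)c4ccccc34)sc2c1` gives 2050 nM 
compound 2 `CCN(CC)Cc1ccc2nc(NC(=O)N/N=C/c3c[nH]c4ccccc34)sc2c1` gives 1900 nM 

Compound 2 at 1900 nM stands level with compound 1 at 2050 nM within the scatter, so neither can be ranked above the other. Compound 3 `CCN(CC)Cc1ccc2nc(NC(=O)N/N=C/c3cn(Cc4ccc(Cl)c(Cl)c4)c4ccccc34)sc2c1` has not yet been measured. It carries 3,4-dichlorobenzyl in place of hydrogen on an aromatic nitrogen of compound 2 3,4-dichlorobenzyl in place of hydrogen on an aromatic nitrogen and keeps the shared core. Within the data shown here, only one measured step bears on this change: a 1.1-fold lower number from compound 1 to compound 2 (0.03 log units; within the scatter) with hydrogen in place of 3-chlorobenzyl on that nitrogen. Among the measured compounds shown here, that step lies within the scatter, and no measured compound carries 3,4-dichlorobenzyl, so the evidence is thin. In this assay no step beyond the scatter is therefore expected, in either direction. The estimated change is a 1.1-fold lower number from compound 2 to compound 3 (0.05 log units; within the scatter) and remains an expectation only. Compound 3 is estimated at 1700 nM (range 650 nM to 4200 nM).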

Compound 3, half-maximal inhibitory concentration: 4490 nM
Compound 3: middle estimate off by 2.6-fold (0.42 log units), on the low side; measured number outside the range, above it.
By their numbers in this assay, from the lowest: compounds 2 and 1 (each within the scatter of the next); then compound 3.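

In this assay, among these compounds, the aromatic nitrogen had so far appeared tolerant, since hydrogen and 3-chlorobenzyl could not be told apart there, but this position does respond to the group it carries: 3,4-dichlorobenzyl gives a 2.4-fold higher number from compound 2 to compound 3 (0.37 log units; beyond the scatter) and so weakens the compound modestly. The single added chloro accounts for a comparable shift, with a 2.2-fold higher number from compound 1 to compound 3 (0.34 log units; beyond the scatter) and thus a step beyond the scatter, so a substituted benzyl on this nitrogen is not enough by itself to raise the number, as compound 1 shows. Nothing measured here explains the change.

The compounds shown leave open whether the rise follows the number of chlorine atoms or their placement, which a plain benzyl or a 4-chlorobenzyl on that nitrogen would help to settle. As far as these compounds go, it also remains open how an amine or a carboxylic acid on the benzyl ring would read in this assay here.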